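A few compounds are considered here, and "the series" means these few. Any claim that something is new, unique, unknown or untested is made for them only; others in the source may bear on it.

In an assay on isolated protein for inhibition of lysosomal alpha-glucosidase (Rattus norvegicus), read by colorimetric assay (a higher number here means a weaker inhibitor, a lower number a stronger inhibitor), the measured compounds stand as follows:
compound 1 `OC[C@@]1(c2ccc(F)cc2)NC[C@@H](O)[C@@H]1O` gives 12000 nM
compound 2 `COc1ccc([C@]2(CO)NC[C@@H](O)[C@@H]2O)cc1` gives 395000 nM
compound 3 `OC[C@@]1(c2cccc(F)c2)NC[C@@H](O)[C@@H]1O` gives 216000 nM

Compound 2 differs from compound 1 by methoxy in place of fluoro on an aromatic carbon, and this step reads a 33-fold higher number from compound 1 to compound 2 (1.52 log units; beyond the scatter). Compound 3 has the same atoms as compound 1 joined differently; the difference between the two cores is not broken down here. Compound 3 gives a higher number than compound 1, while compound 3 and compound 2 lie within the scatter of each other.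

Compound 4 `COc1cccc([C@]2(CO)NC[C@@H](O)[C@@H]2O)c1` is not yet measured and differs from compound 3 by methoxy in place of fluoro on an aromatic carbon. This is the same kind of change as from compound 1 to compound 2, but the place differs: there the group sits para to a group of 9 heavy atoms, here meta to a group of 9 heavy atoms. The step from compound 3 to compound 4 is expected to be a 5.6-fold higher number from compound 3 to compound 4 (0.74 log units; beyond the scatter), in the direction of a 33-fold higher number from compound 1 to compound 2 (1.52 log units; beyond the scatter) but smaller, because compound 3 already gives 216000 nM. Compound 4 is therefore estimated at 1200000 nM, between 250000 nM and 6000000 nM.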

Compound 4, half-maximal inhibitory concentration: 52000 nM
Estimate against measurement, compound 4: 23-fold (1.36 log units) above; measured number below the stated range.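

In this assay, methoxy in place of fluoro on an aromatic carbon, meta to a group of 9 heavy atoms, gives a 4.2-fold lower number from compound 3 to compound 4 (0.62 log units; beyond the scatter) and so reverses the direction seen on the other pair: the same change on two cores in this assay, a 33-fold higher number (1.52 log units; beyond the scatter) from compound 1 to compound 2 and a 4.2-fold lower number (0.62 log units; beyond the scatter) from compound 3 to compound 4, 140-fold (2.14 log units) apart, beyond the scatter of two such steps. This change therefore cannot be carried from one pair of this series to the other, either in size or in direction. Two pairs do not give a general rule for where on the ring the change helps, and they do not show why the direction reverses.

As far as these compounds go, whether a chloro, an amine or a carboxylic acid at these two ring places would also reverse direction remains open. Also open, from the compounds shown here alone, is whether the reversal extends to any group other than methoxy.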